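Swapping chloro for trifluoromethoxy on the phenoxy ring

The source may hold more compounds than are shown below. What is called first, only, known or untested is meant among the compounds shown, and "the series" means these compounds.

Measured so far:
compound 1 `Cc1nn(C)c(Oc2ccc(F)cc2)c1/C=N\OCc1c(Cl)c(-c2ccc(F)cc2)nn1C` gives 8020 nM
compound 2 `Cc1nn(C)c(Oc2ccc(Cl)cc2)c1/C=N\OCc1c(Cl)c(-c2ccc(Cl)cc2)nn1C` gives 4670 nM

Both numbers come from a functional assay on HCT-116 cells (Homo sapiens) for antiproliferative activity, read by MTT assay, with a stated time of 72 h; on this read-out lower numbers stand for stronger inhibition and higher numbers for weaker inhibition. Compound 2 has the lower of the two, but its gap to compound 1 lies within the usual scatter, so the two cannot be told apart. Compound 3 `Cc1nn(C)c(Oc2ccc(OC(F)(F)F)cc2)c1/C=N\OCc1c(Cl)c(-c2ccc(Cl)cc2)nn1C` differs from compound 2 by trifluoromethoxy in place of chloro on an aromatic carbon. For the measured compounds named here, no step of this kind has been measured here, so the size of the change is unknown; the expected step from compound 2 to compound 3 is a 1.1-fold higher number from compound 2 to compound 3 (0.03 log units; within the scatter), not beyond the scatter. For compound 3 in this assay the expected value is 5000 nM, within a range of 2000 nM to 15000 nM.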

Compound 3, half-maximal inhibitory concentration: 3020 nM
Compound 3: the middle estimate sits 1.7-fold (0.22 log units) above what was measured; the measured number falls inside the stated range.
By their numbers in this assay, from the lowest: compounds 3, 2 and 1 (each within the scatter of the next, the first and the last beyond it).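

In this assay, going from 4-chlorophenoxy to 4-(trifluoromethoxy)phenoxy gives a 1.5-fold lower number from compound 2 to compound 3 (0.19 log units; within the scatter), so the two compounds cannot be told apart. This position thus takes trifluoromethoxy, with five heavy atoms against one for chloro, without a change that can be read. Nothing measured here speaks to the reason. On these data alone, whether an amine or a carboxylic acid on this aromatic carbon would fare the same remains open. So does whether the same swap on the other 4-chlorophenyl group would leave the number within the scatter.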